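Fluoro to methoxy on the benzylamine side chain

This account rests on a few compounds, and the source may have more. Where it says the series, first, only, none or still open, it means among the compounds named here.

Within the data shown here, compound 2, `Nc1cc(N)c2nc(-c3ccccc3)c(NCc3ccc(F)cc3)nc2c1`, gives 11500 nM in a functional assay on NCI-H322M cells (Homo sapiens) for inhibition, read by sulforhodamine B assay, with a stated time of 48 h (a higher number here means a weaker inhibitor of growth, a lower number a stronger inhibitor of growth), and stands lowest of the two numbers measured so far; compound 1, `COc1ccc(CNc2nc3cc(N)cc(N)c3nc2-c2ccccc2)cc1OC`, gives 47900 nM. Among the measured compounds shown here, the only measured step, a 4.2-fold lower number from compound 1 to compound 2 (0.62 log units; beyond the scatter), bears on the change now considered. Compound 3, `COc1ccc(CNc2nc3cc(N)cc(N)c3nc2-c2ccccc2)cc1`, differs from compound 2 by methoxy in place of fluoro on an aromatic carbon. Since that earlier step moved the number down, the present change is expected to move it partly back up, by a 2.2-fold higher number from compound 2 to compound 3 (0.34 log units; beyond the scatter). Compound 3 is therefore estimated at 25000 nM, within 9000 nM to 70000 nM.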

Compound 3, concentration for total growth inhibition: 52500 nM
Estimate against measurement, compound 3: 2.1-fold (0.32 log units) below, and the stated range covers the measured number.
By their numbers in this assay, from the lowest: compound 2; then compounds 1 and 3 (each within the scatter of the next).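

In this assay methoxy in place of fluoro at this place gives a 4.6-fold higher number from compound 2 to compound 3 (0.66 log units; beyond the scatter) and so reverses the gain that compound 2 showed over compound 1. Taking away the second methoxy gives a 1.1-fold higher number from compound 1 to compound 3 (0.04 log units; within the scatter) and so brings no change that can be told from scatter, which means that compound 1 and compound 3 stand level. No evidence is available that explains this result. The compounds shown leave open how chloro, hydroxyl or an amine at this place would compare with fluoro and methoxy.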